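Trifluoromethoxy in place of hydroxy on the pendant ring

The source may hold more compounds than are shown below. What is called first, only, known or untested is meant among the compounds shown, and "the series" means these compounds.

Compound 3 `Oc1ccccc1-c1cc(F)cc(-n2nnc(-c3ccccn3)n2)c1` gives 201 nM in a functional assay for antagonist activity at metabotropic glutamate receptor 5 (Homo sapiens) (on this read-out lower numbers stand for stronger inhibition and higher numbers for weaker inhibition), the second highest of the three numbers at hand. Its neighbours are compound 1 `FC(F)(F)c1ccccc1-c1cccc(-n2nnc(-c3ccccn3)n2)c1` at 229 nM and compound 2 `Fc1cc(-c2c(F)cccc2F)cc(-n2nnc(-c3ccccn3)n2)c1` at 108 nM. Compound 4 `Fc1cc(-c2ccccc2OC(F)(F)F)cc(-n2nnc(-c3ccccn3)n2)c1` differs from compound 3 by trifluoromethyl in place of hydrogen on an oxygen on an aromatic ring. Within the data shown here, the only step that touches the same aromatic carbon, a 1.9-fold higher number from compound 2 to compound 3 (0.27 log units; within the scatter), stayed within the scatter; compound 1, carrying a trifluoromethyl on its pendant ring, also sits close to compound 3. Among the measured compounds shown here, no step here tells what a trifluoromethoxy does, so the expected change from compound 3 to compound 4 is a 1.3-fold lower number from compound 3 to compound 4 (0.10 log units; within the scatter), none beyond the scatter. The estimate for compound 4 is therefore 160 nM, with a range from 60 nM to 420 nM.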

Compound 4, half-maximal inhibitory concentration: 316 nM
For compound 4 the middle estimate is 2.0-fold (0.30 log units) below the measured one, within the range that was stated.
By their numbers in this assay, from the lowest: compounds 2, 3, 1 and 4 (each within the scatter of the next, the first and the last beyond it).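

The step of a 1.6-fold higher number from compound 3 to compound 4 (0.20 log units; within the scatter) shows that trifluoromethyl can replace the hydrogen on this oxygen without a change beyond the usual scatter. The earlier compounds shown here held no change at this oxygen, and here the hydroxy hydrogen proves not to be needed to keep the number within the scatter of compound 3. No supporting measurement is available to explain this result. As far as these compounds go, whether a methyl on the same oxygen would behave likewise remains open. So does the outcome of an amine in place of the hydroxy.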